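From Chloro to Bromo: A Single Atom Exchanged

This account rests on a few compounds, and the source may have more. Where it says the series, first, only, none or still open, it means among the compounds named here.

In a functional assay on HepG2 cells (Homo sapiens) for antiproliferative activity, read by MTT assay, with a stated time of 48 h (a higher number here means a weaker inhibitor, a lower number a stronger inhibitor), compound 1 `O=[N+]([O-])c1cc(C(F)(F)F)cc([N+](=O)[O-])c1Oc1ccccc1/C=N\OCc1ccccc1` gives 1330 nM and compound 2 `O=[N+]([O-])c1cc(C(F)(F)F)cc([N+](=O)[O-])c1Oc1ccc(Cl)cc1/C=N\OCc1ccccc1` gives 1790 nM. Within the data shown here, these are the only two measurements so far. They lie within the usual scatter of repeated measurements, so the data do not separate compound 2 from compound 1.

The next structure, compound 3 `O=[N+]([O-])c1cc(C(F)(F)F)cc([N+](=O)[O-])c1Oc1ccc(Br)cc1/C=N\OCc1ccccc1`, keeps all of compound 2 except for one atom: bromo in place of chloro on an aromatic carbon. Among the measured compounds shown here, only one measured step bears on this change, and it concerns the same aromatic carbon, where chloro stands in place of hydrogen. That step is a 1.3-fold higher number from compound 1 to compound 2 (0.13 log units; within the scatter), so it did not rise above the scatter. For the measured compounds named here, no bromo compound has been measured yet, and a single step is a thin guide. Resting on that step alone, no shift beyond the scatter is expected in this assay when bromo replaces chloro.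

The estimated change is a 1.0-fold higher number from compound 2 to compound 3 (0.00 log units; within the scatter), which amounts to no real movement. Compound 3 is expected to give about 1800 nM, with an estimated range of 950 nM to 3400 nM.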

Compound 3, half-maximal inhibitory concentration: 1180 nM
Compound 3: middle estimate off by 1.5-fold (0.18 log units), on the high side; the measured number falls inside the stated range.
By their numbers in this assay, from the lowest: compounds 3, 1 and 2 (each within the scatter of the next).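

In this assay, the exchange of chloro for bromo gives a 1.5-fold lower number from compound 2 to compound 3 (0.18 log units; within the scatter) and still stays short of a real difference, and bromo in place of hydrogen gives a 1.1-fold lower number from compound 1 to compound 3 (0.05 log units; within the scatter) with the same outcome. With three compounds now in hand, this aromatic carbon has carried hydrogen, chloro and bromo, and every pair among compounds 1, 2 and 3 lies within the scatter, so neither halogen can be told apart from the other or from hydrogen by this read-out. The measurements shown offer nothing independent that would explain these numbers, and with steps this small there is no difference here that calls for explaining.

From the compounds shown here alone, all of this covers only a narrow set of substituents, so it remains open whether an amine, a methoxy group or a carboxylic acid on this same aromatic carbon would shift the number beyond the scatter. Going by these compounds, it also remains open whether the flat response seen here holds when the same three substituents are paired with changes elsewhere on the shared core.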